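The source may hold more compounds than are shown below. What is called first, only, known or untested is meant among the compounds shown, and "the series" means these compounds.

Compound 1 `c1csc(-c2ccccc2NCC2=NCCN2)c1` in a functional assay for activation of Alpha-1B adrenergic receptor (Homo sapiens), read by calcium flux (on this read-out lower numbers stand for an effect already at smaller amounts and higher numbers for an effect only at larger amounts of compound), gives 5.75 nM. Compound 2 `Cc1nc(-c2ccccc2NCC2=NCCN2)co1` gives only a limit in this assay, < 5020 nM. The step that the limit leaves unreadable from compound 1 to compound 2 is unreadable on that account, as the limit of < 5020 nM in this assay, at which 1 of the 2 values shown sits, sets the bound. Compound 3 `Cc1cc(-c2ccccc2NCC2=NCCN2)on1` differs from compound 2 by 3-methyl-1,2-oxazol-5-yl in place of 2-methyl-1,3-oxazol-4-yl on an aromatic carbon. For the measured compounds named here, no measured step bears on this change, and compound 2 itself stands only at a limit, so no direction beyond the scatter can be set. The estimate for compound 3 in this assay is 300 nM, expected to fall between 20 nM and 5000 nM. The step that the limit leaves unreadable from compound 2 to compound 3 is expected with the same wide uncertainty.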

Compound 3, half-maximal effective concentration: 95.5 nM
For compound 3 the middle estimate is 3.1-fold (0.50 log units) above the measured one; the measured number falls inside the stated range.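

In this assay, for the compounds shown here, 3-methyl-1,2-oxazol-5-yl on this aromatic carbon gives the first readable comparison with thiophen-2-yl, a 17-fold higher number from compound 1 to compound 3 (1.22 log units; beyond the scatter): the change carries a large cost, yet compound 3 still gives a numerical value. Compound 2 gives only a limit, < 5020 nM. Its steps to compound 1 and compound 3 therefore cannot be read, so the two same-atom groups cannot be ranked: the limit of < 5020 nM in this assay, at which 1 of the 3 values shown sits.

From the compounds shown here alone, whether the methyl contributes to the step from thiophen-2-yl stays open. So does whether an unsubstituted 1,2-oxazol-5-yl or a phenyl at this place would narrow it.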